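The compounds below may be only part of what the source reports. "The series", "measured", "known", "first", "only" and "open" are said of these compounds alone.

In a functional assay, read by spectrophotometry, with a stated time of 6 min (a lower number here means that less compound is needed, a higher number that more compound is needed for the effect), compound 1 `COc1c(C)cc(O)cc1/C=C/C(C)(O)CC(=O)/C=C(\C)CCCC(C)C(=O)/C=C/C(C)(C)O` gives 24400 nM. Compound 2 `COc1c(C)cc(O)cc1/C=C/C(C)(O)CC(=O)/C=C(/C)CCCC(C)=O` gives 55900 nM, the higher of the two numbers, and the gap between them lies beyond the scatter. Compound 3 `COc1c(C)cc(O)cc1/C=C/C(C)(O)CC(=O)/C=C(\C)CCCC(C)=O` has the same atoms and bonds as compound 2: the two compounds have the same atoms and bonds; at least one stereo element is drawn with a configuration in one of them and without one in the other: 1 of 3 stereo elements differ; a double bond is drawn Z in compound 2 and E in compound 3. Among the compounds with values here, no measured pair isolates a change of this kind, so no step beyond the scatter is expected in this assay, with a slight lean towards a lower number. The expected move is a 1.4-fold lower number from compound 2 to compound 3 (0.15 log units; within the scatter). For compound 3, the estimate is 40000 nM, with an expected range of 17000 nM to 95000 nM.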

Compound 3, half-maximal effective concentration: 44700 nM
Estimate against measurement, compound 3: 1.1-fold (0.05 log units) below; the measured number falls inside the stated range.
By their numbers in this assay, from the lowest: compounds 1, 3 and 2 (each within the scatter of the next, the first and the last beyond it).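

Changing this double bond from Z to E gives, in this assay, a 1.3-fold lower number from compound 2 to compound 3 (0.10 log units; within the scatter), so no effect of the geometry can be read at this place. With the double bond as in compound 3 and compound 1, acetyl in place of 1-((3-hydroxy-3-methylbut-1-en-1-yl)carbonyl)ethyl gives a 1.8-fold higher number from compound 1 to compound 3 (0.26 log units; within the scatter), so this exchange, read on its own, also stays inside the scatter. One caution applies to the geometry comparison: the fact that one of compounds 2 and 3 is drawn with a defined configuration and the other without, at the place where they differ.

Still open, going by these compounds, is whether a carboxylic acid or an amine in place of the acetyl, or a longer chain at that place, would give a step beyond the scatter in this assay.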